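Series notes: methoxy in place of chloro on compound 2

A few compounds are considered here, and "the series" means these few. Any claim that something is new, unique, unknown or untested is made for them only; others in the source may bear on it.

Three compounds have numbers in an assay on HeLa cells for displacement of a labelled ligand from 5-hydroxytryptamine receptor 6 (Homo sapiens); a lower number here means a stronger inhibitor, a higher number a weaker inhibitor. Compound 1 `CN1CCN(c2ccc3[nH]nc(S(=O)(=O)c4ccc(F)cc4)c3c2)CC1` gives 5.2 nM, and compound 3 `CN1CCN(c2cccc3c(S(=O)(=O)c4cccc5ccccc45)n[nH]c23)CC1` gives 4.6 nM; these two lie within the scatter of each other. Compound 2 `O=S(=O)(c1ccc(Cl)cc1)c1n[nH]c2cccc(N3CCNCC3)c12` gives 125 nM, the highest of the three and beyond the scatter from both others.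

Compound 4 `COc1ccc(S(=O)(=O)c2n[nH]c3cccc(N4CCNCC4)c23)cc1` keeps the core and the piperazine of compound 2 and differs in one place: methoxy in place of chloro on an aromatic carbon. For the measured compounds named here, no measured pair shows this change on its own, so its size cannot be read off the numbers already in hand. The expected step of a 1.3-fold lower number from compound 2 to compound 4 (0.10 log units; within the scatter) is small, in either direction, and likely within the scatter. Compound 4 is accordingly estimated at 100 nM, with a range from 30 nM to 350 nM.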

Compound 4, inhibition constant: 88 nM
The estimate for compound 4 lay 1.1-fold (0.06 log units) above the measured number, and the stated range covers the measured number.
By their numbers in this assay, from the lowest: compounds 3 and 1 (each within the scatter of the next); then compounds 4 and 2 (each within the scatter of the next).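

In this assay, for the compounds shown here, the change from 4-chlorophenyl to 4-methoxyphenyl gives a 1.4-fold lower number from compound 2 to compound 4 (0.15 log units; within the scatter) and is the first one-place comparison. At this position, on the core of compound 2, methoxy and chloro therefore cannot be told apart by their numbers. No measured evidence available bears on this result.

From the compounds shown here alone, whether an amine or a carboxylic acid at the same position would also leave the number within the scatter remains open. So does whether methoxy in place of chloro would give a similar step on the core of compound 1.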